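A few compounds are considered here, and "the series" means these few. Any claim that something is new, unique, unknown or untested is made for them only; others in the source may bear on it.

In a functional assay on MCF7 cells (Homo sapiens) for antiproliferative activity, read by MTT assay, with a stated time of 72 h (a lower number here means a stronger inhibitor of growth, a higher number a weaker inhibitor of growth), two compounds have been measured so far. Compound 1, with the structure `Cc1ccc(Nc2nc3ncccc3n2Cc2ccccc2)cc1[N+](=O)[O-]`, gives 27800 nM. Compound 2, with the structure `Cn1nc(-c2ccnc(Nc3cccc(O)c3)n2)c2ccccc21`, gives 28200 nM. The two numbers stand so close together that they fall within the ordinary scatter of this kind of measurement, so neither compound can be said to inhibit growth more than the other.

Compound 3, with the structure `Cn1nc(-c2ccnc(Nc3cccc(Cl)c3)n2)c2ccccc21`, has not yet been measured. It differs from compound 2 in one place: chloro in place of hydroxy on an aromatic carbon. Among the compounds with values here, no measured pair shows this exchange, so its effect can only be guessed. A single-atom swap of this sort is expected to move the number little, and the step from compound 2 to compound 3 is estimated at a 1.4-fold lower number from compound 2 to compound 3 (0.15 log units; within the scatter), in this assay. Compound 3 is therefore expected to give about 20000 nM, with a likely range from 6000 nM to 60000 nM.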

Compound 3, concentration for 50% growth inhibition: 5970 nM
Compound 3: the middle estimate sits 3.4-fold (0.53 log units) above what was measured, outside the stated range (below it).
By their numbers in this assay, from the lowest: compound 3; then compounds 1 and 2 (each within the scatter of the next).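

In this assay the place on the 3-hydroxyphenyl ring turns out to respond to a change of a single atom: chloro in place of hydroxy gives a 4.7-fold lower number from compound 2 to compound 3 (0.67 log units; beyond the scatter) in this one pair. Compound 3 has no hydrogen-bond donor at this place, so in this pair the hydroxy hydrogen is not needed for growth inhibition in these cells. No measurement at hand gives a reason for the drop in the number.

Within the data shown here, with only one exchange at this place, it stays open whether chloro itself matters or whether losing hydroxy is enough; a plain hydrogen, a methyl, a fluoro or a methoxy there would help to separate the two. From the compounds shown here alone, whether chloro would do the same at other places on this ring also remains open.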